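Swapping nitro for chloro where only a limit exists

The source may report more compounds than this note shows. Statements on the series, on what has been measured and on what is new or still open speak of the compounds shown alone.

Of the compounds shown here, three have been tested in a functional assay on the whole organism with Mus musculus as the target, in the rotarod test; on this read-out lower numbers stand for an effect already at smaller amounts and higher numbers for an effect only at larger amounts of compound. Compound 1 `COc1cc2c(cc1OC)C(c1ccc(Br)cc1)=NNC(=O)C2`, which carries bromo, gives 226 umol/kg. Compound 2 `COc1cc2c(cc1OC)C(c1ccccc1)=NN(C)C(=S)C2` gives 97.1 umol/kg. Compound 3 `COc1cc2c(cc1OC)C(c1ccc([N+](=O)[O-])cc1)=NNC(=O)C2`, which carries nitro, gives > 150 umol/kg, and this value is a limit of the assay, not a number. So compound 3 has no exact place on the scale, and any comparison with it stays open.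

The change to follow leads to compound 4 `COc1cc2c(cc1OC)C(c1ccc(Cl)cc1)=NNC(=O)C2`: chloro in place of nitro on an aromatic carbon. In short, chloro takes the place of nitro on an aromatic carbon. Among the compounds with values here, only one measured step bears on this, a step that the limit leaves unreadable from compound 1 to compound 3, and it also swaps the group on that aromatic carbon. Its size cannot be read, so it offers no size or direction to carry over to the new change in this assay. Within the data shown here, compound 1 at 226 umol/kg is the one readable value at the far end of that step, so the estimate leans on it.

The estimated change is a step that the limit leaves unreadable from compound 3 to compound 4, and its size stays uncertain while its starting point is only a limit. Compound 4 is estimated at 200 umol/kg, with an expected range from 90 umol/kg to 450 umol/kg.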

Compound 4, dose for half-maximal effect: 240 umol/kg
Compound 4: the middle estimate sits 1.2-fold (0.08 log units) below what was measured; low and high end bracket the measured number.
By their numbers in this assay, from the lowest: compound 2; then compounds 1 and 4 (each within the scatter of the next).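

In this assay, within the data shown here, this is the first change at this aromatic carbon, para to a large group, whose size can be read: a 1.1-fold higher number from compound 1 to compound 4 (0.03 log units; within the scatter). Chloro and bromo therefore cannot be told apart at this position, and the shared core carries either group with no difference that stands out from the usual scatter of the assay. The steps that touch compound 3 cannot be read, and nitro stays unplaced against both, because compound 3 has only a limit and not a number: the limit of > 150 umol/kg in this assay, at which 1 of the 4 values shown sits.

This single pair of close values says nothing about how far the read-out could move at this carbon, and it cannot be stretched into a rule for other groups. Going by these compounds, what an amine, a carboxylic acid or a longer chain would do in this place stays open, as does the effect of having no group there at all on this same core, since compound 2 has no group at this carbon but also differs from compounds 1 and 4 elsewhere.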